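Sulfonyl aryl change in a piperazine chalcone series

The source may hold more compounds than are shown below. What is called first, only, known or untested is meant among the compounds shown, and "the series" means these compounds.

In a functional assay on the whole organism (strain Kunming) for inhibition, with Mus musculus as the target, with a stated time of 1 h, at a dose of 40 mg/kg by the oral route (a higher number here means more inhibition at the dose given (going by the name of the read-out), a lower number less inhibition), compound 3 `Cc1ccc(S(=O)(=O)N2CCN(c3ccc(C(=O)/C=C/c4ccccc4)cc3)CC2)cc1` gives 30.8%, the highest of three numbers. Compound 1 `O=C(/C=C/c1ccccc1)c1ccc(N2CCN(c3cccc(Cl)c3Cl)CC2)cc1` gives 30.7%, and the difference a number 0.1 percentage points higher from compound 1 to compound 3 (within the scatter) lies within the scatter. Compound 2 `O=C(/C=C/c1ccccc1)c1ccc(N2CCN(c3ccccc3Cl)CC2)cc1` gives 4.71%, and the step of a number 26.1 percentage points higher from compound 2 to compound 3 (beyond the scatter) lies beyond it; likewise a number 26 percentage points lower from compound 1 to compound 2 (beyond the scatter) lies beyond it. Compound 4 `O=C(/C=C/c1ccccc1)c1ccc(N2CCN(S(=O)(=O)c3ccc4ccccc4c3)CC2)cc1` differs from compound 3 by naphthalen-2-yl in place of 4-methylphenyl on a sulfonyl sulfur. Among the compounds with values here, no measured step alters the group on the sulfonyl sulfur; the measured steps concern the group on the amine nitrogen in a ring, so none bears directly on this change. Compound 4 is therefore expected to stay near compound 3, with the estimated step of a number 0.8 percentage points lower from compound 3 to compound 4 (within the scatter) within the scatter. For compound 4 the estimate in this assay is 30%, between 15% and 45%.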

Compound 4, a percentage reported as inhibition, in the whole organism at one dose (the size of the read-out at that dose, not a potency): 35%
For compound 4 the middle estimate is 5 percentage points below the measured one; measured number inside the range.
By their numbers in this assay, from the lowest: compound 2; then compounds 1, 3 and 4 (each within the scatter of the next).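

In this assay, within the data shown here, the change on the sulfonyl sulfur gives a number 4.2 percentage points higher from compound 3 to compound 4 (within the scatter), the first measured step at this position. Naphthalen-2-yl, with two six-membered aromatic rings, thus reads the same as 4-methylphenyl, with one, within the scatter, and this holds for these two groups only. Nothing measured here offers an explanation for this result. Still open, on these data alone, is whether a sulfonyl sulfur bearing a methyl group or a longer alkyl chain would hold the read-out, and the same question applies to a phenyl ring carrying an amine or a carboxylic acid.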